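Notes on phenyl in place of thiophen-2-yl

This account rests on a few compounds, and the source may have more. Where it says the series, first, only, none or still open, it means among the compounds named here.

Measured in an ADME assay on L6 cells (Rattus norvegicus) for cytotoxicity, read by fluorescence and resazurin assay, with a stated time of 70 h; on this read-out lower numbers stand for stronger inhibition and higher numbers for weaker inhibition:
- compound 1 `N#Cc1ccc(-c2nc3cc(NC(=N)N)ccc3[nH]2)cc1`: > 100 ug/mL
- compound 2 `N=C(N)Nc1ccc2[nH]c(-c3ccc(F)c(F)c3)nc2c1`: > 100 ug/mL
- compound 3 `N=C(N)Nc1ccc2[nH]c(-c3ccc(-c4cccs4)s3)nc2c1`: 49.9 ug/mL

Within the data shown here, compound 3 gives 49.9 ug/mL, the only true number in this small set. The entries for the other two compounds are limits and not numbers: the limit of > 100 ug/mL in this assay, at which 2 of the 3 values shown sit.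

The next compound to be read is compound 4 `N=C(N)Nc1ccc2[nH]c(-c3ccc(-c4ccccc4)s3)nc2c1`. It carries phenyl in place of thiophen-2-yl on an aromatic carbon of a five-membered aromatic ring with 1 sulfur. The counted difference is phenyl in place of thiophen-2-yl on an aromatic carbon.

Among the measured compounds shown here, no measured pair differs in one place only, so the data give no direct size for a step of this kind. The expectation therefore rests on compound 3 at 49.9 ug/mL as the only numeric anchor. In this assay no step beyond the usual scatter is expected, in either direction. The expected change is a 1.1-fold lower number from compound 3 to compound 4 (0.04 log units; within the scatter). For compound 4 the estimated value is 45 ug/mL. The expected range for compound 4 runs from 17 ug/mL to 100 ug/mL.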

Compound 4, half-maximal inhibitory concentration: 48.4 ug/mL
The estimate for compound 4 lay 1.1-fold (0.03 log units) below the measured number; measured number inside the range.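

In this assay the series yields its first readable step, a 1.0-fold lower number from compound 3 to compound 4 (0.01 log units; within the scatter) for phenyl in place of thiophen-2-yl on an aromatic carbon of a five-membered aromatic ring with 1 sulfur. Among these compounds, at this place, next to the ring sulfur, a six-membered aromatic ring of carbon only and a five-membered aromatic ring with 1 hetero atom cannot be told apart on this read-out, which the earlier compounds could not show. Compound 1 and compound 2 differ from these two in more than one place and stand only as limits, so no steps to them can be read: the limit of > 100 ug/mL in this assay, at which 2 of the 4 values shown sit.

What the compounds shown leave open is whether this insensitivity holds for groups of another kind at the same place, such as an amine, a carboxylic acid or a longer alkyl chain. They also leave open whether the same exchange of rings would read the same way on a different core, since the series offers this single pair.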